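Fluoro to hydroxy on the anilino ring: working notes

This account rests on a few compounds, and the source may have more. Where it says the series, first, only, none or still open, it means among the compounds named here.

Measured so far:
compound 1 `O=C(/C=C\Nc1ccc(F)cc1)c1cn(-c2ccccc2)nc1-c1ccccc1` — 34200 nM
compound 2 `O=C(/C=C\Nc1ccc(F)cc1)c1cn(-c2ccccc2)nc1-c1ccc(Cl)cc1` — > 50000 nM
compound 3 `O=C(/C=C\Nc1ccc(O)cc1)c1cn(-c2ccccc2)nc1-c1ccc(Cl)cc1` — not yet measured

In an ADME assay on HaCaT cells (Homo sapiens) for antiproliferative activity, read by MTT assay, with a stated time of 48 h (a lower number here means a stronger inhibitor, a higher number a weaker inhibitor), compound 1 gives 34200 nM. For compound 2 the assay reports only a limit, > 50000 nM. Going by the values given here, the single measured step, an at least 1.4-fold higher number from compound 1 to compound 2 (0.16 log units; that floor lies within the scatter), runs into (the limit of > 50000 nM in this assay, at which 1 of the 2 values shown sits), so compound 2 stands at the weak end of what the assay can resolve.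

Compound 3 differs from compound 2 by hydroxy in place of fluoro on an aromatic carbon. Among the compounds with values here, no measured step touches the group that changes here: the only step in hand concerns chloro in place of hydrogen on a different ring and says nothing about this exchange. Accordingly no step beyond the scatter is expected in this assay in either direction. For compound 3 the estimate is 50000 nM, with a range of 20000 nM to 150000 nM. That estimate means an expected step of a number no higher from compound 2 to compound 3 (the limit leaves the size open). A limit rather than a number is the more probable outcome for compound 3.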

Compound 3, half-maximal inhibitory concentration: 22600 nM
The estimate for compound 3 lay 2.2-fold (0.34 log units) above the measured number; low and high end bracket the measured number.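

Hydroxy in place of fluoro, on an aromatic carbon para to a large group, gives an at least 2.2-fold lower number from compound 2 to compound 3 (0.34 log units; beyond the scatter) in this assay. This position therefore responds to the exchange, which the earlier chloro step, made on a different ring, could not show. Compound 2 gives only a limit, > 50000 nM, so the step is a floor and its full size stays unread: the limit of > 50000 nM in this assay, at which 1 of the 3 values shown sits.

Whether the same exchange would give a comparable step in the compound without the chloro stays open, as does any reason for the step. How a methoxy or an amine at this position would read in this assay also stays open, so the shown pair cannot say whether hydroxy is specifically required or whether other replacements for fluoro would serve as well.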